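From cyano to 5-chloro-1H-benzimidazol-2-yl on the shared core

The compounds below may be only part of what the source reports. "The series", "measured", "known", "first", "only" and "open" are said of these compounds alone.

In a functional assay on HL-60 cells (Homo sapiens) for antiproliferative activity, read by MTT assay, with a stated time of 48 h (on this read-out higher numbers stand for weaker inhibition and lower numbers for stronger inhibition), compound 3 (`CN(C)CCCCn1c(N)c(C#N)c2nc(C#N)c(C#N)nc21`) gives 12900 nM as its reading, the higher of the two actual numbers in this small set. Compound 2 (`CN(C)CCCCCn1c(N)c(-c2nc3ccccc3[nH]2)c2nc(C#N)c(C#N)nc21`) reads 3420 nM in the same test, a lower number, with the gap beyond the scatter. For compound 1 (`N#Cc1nc2c(-c3nc4ccccc4[nH]3)c(N)n(CCCO)c2nc1C#N`) the test gives only a limit, > 50000 nM in this case.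

Compound 4 (`CN(C)CCCCn1c(N)c(-c2nc3cc(Cl)ccc3[nH]2)c2nc(C#N)c(C#N)nc21`) keeps the 4-(dimethylamino)butyl group of compound 3 but carries 5-chloro-1H-benzimidazol-2-yl in place of cyano on an aromatic carbon at the same place.

Among the compounds with values here, no measured step makes this exact exchange. Within the data shown here, the only step available is an at least 14-fold lower number from compound 1 to compound 2 (1.16 log units; beyond the scatter) and it is large, but it concerns the chain and rests on the limit of > 50000 nM in this assay, at which 1 of the 3 values shown sits, at its starting end. It therefore bears on compound 4 only indirectly, by showing that a dimethylamino chain can go with a measurable number. Compound 2 also carries an aromatic group at the changing place, without the chlorine, and its 3420 nM reading suggests a lower number for compound 4 than for compound 3.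

The expected change is a 4.3-fold lower number from compound 3 to compound 4 (0.63 log units; beyond the scatter) as a rough estimate, in the direction of stronger inhibition. For compound 4 the estimated value is 3000 nM with an expected range from 900 nM to 10000 nM in this test.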

Compound 4, half-maximal inhibitory concentration: 1480 nM
The estimate for compound 4 lay 2.0-fold (0.31 log units) above the measured number, and the stated range covers the measured number.
By their numbers in this assay, from the lowest: compound 4; then compound 2; then compound 3. At a limit, above all of these: compound 1.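

In this assay, the exchange at this place now has a direct reading with the 4-(dimethylamino)butyl group held unchanged, and it gives an 8.7-fold lower number from compound 3 to compound 4 (0.94 log units; beyond the scatter). Within the data shown here, the only earlier step concerned the chain, whereas this one concerns the aromatic carbon next to the ring atom that bears an amino group, and it shows that cyano is not needed there for a measurable number: the much larger 5-chloro-1H-benzimidazol-2-yl goes with the lower reading. Nothing measured here explains the size or direction of this step.

Compound 2 differs from compound 4 both in its chain and in lacking the chlorine, and no pair shown separates the share of the chlorine from that of the ring system that carries it. Still open, as far as these compounds go, is how the same group without the chlorine would read on the 4-(dimethylamino)butyl chain, and how a fluorine, a methoxy group or a carboxylic acid would read in place of that chlorine.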